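This account rests on a few compounds, and the source may have more. Where it says the series, first, only, none or still open, it means among the compounds named here.

For the measured compounds named here, compound 3 `NC(=O)COc1cc(CNc2nc3c(N)ncnc3n2[C@@H]2O[C@H](CO)[C@@H](O)[C@H]2O)ccc1-c1ccccc1` gives 5500 nM in an assay on COS-7 cells for inhibition of sodium/nucleoside cotransporter 2 (Homo sapiens), read by scintillation counting (on this read-out lower numbers stand for stronger inhibition and higher numbers for weaker inhibition), the highest of the three numbers measured so far. Compound 1 `Nc1ncnc2c1nc(NCc1ccc(-c3ccccc3)c(O)c1)n2[C@@H]1O[C@H](CO)[C@@H](O)[C@H]1O` gives 1200 nM, and compound 2 `CCCOc1cc(CNc2nc3c(N)ncnc3n2[C@@H]2O[C@H](CO)[C@@H](O)[C@H]2O)ccc1-c1ccccc1` gives 5200 nM. The step from compound 3 to compound 4 `Nc1ncnc2c1nc(NCc1ccc(-c3ccccc3)c(OCCCCCO)c1)n2[C@@H]1O[C@H](CO)[C@@H](O)[C@H]1O` is 4-hydroxybutyl in place of carbamoyl on a saturated chain carbon bound to an oxygen on an aromatic ring. Bearing on it: placing a group on the oxygen on the aromatic ring raised the number beyond the scatter in both cases, a 4.3-fold higher number from compound 1 to compound 2 (0.64 log units; beyond the scatter) and a 4.6-fold higher number from compound 1 to compound 3 (0.66 log units; beyond the scatter), whereas changing what sits on that chain carbon stayed within the scatter, a 1.1-fold higher number from compound 2 to compound 3 (0.02 log units; within the scatter). Two different groups at this place thus landed close together, and a further change of this kind is expected to do likewise, a 1.1-fold lower number from compound 3 to compound 4 (0.04 log units; within the scatter). Compound 4 is therefore expected at 5000 nM, with a range from 2000 nM to 12000 nM.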

Compound 4, half-maximal inhibitory concentration: 1600 nM
Estimate against measurement, compound 4: 3.1-fold (0.49 log units) above; measured number below the stated range.
By their numbers in this assay, from the lowest: compounds 1 and 4 (each within the scatter of the next); then compounds 2 and 3 (each within the scatter of the next).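

In this assay there is a 3.4-fold lower number from compound 3 to compound 4 (0.54 log units; beyond the scatter) and a 3.3-fold lower number from compound 2 to compound 4 (0.51 log units; beyond the scatter) as well, so what sits on this oxygen can shift the number beyond the scatter. With a 1.3-fold higher number from compound 1 to compound 4 (0.12 log units; within the scatter) as the third step, a group on this oxygen does not by itself raise the number: compounds 2 and 3 show that rise and compound 4 goes against it. On these data alone, a plain pentyl chain would separate the effect of chain length from that of the hydroxyl, and an amine or a carboxylic acid on the chain remains open. No evidence at hand gives a cause for these steps.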